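Solubility in a fluorinated aryl-pyrazole oxazolidinone series

A few compounds are considered here, and "the series" means these few. Any claim that something is new, unique, unknown or untested is made for them only; others in the source may bear on it.

Compound 1 `CN(CCC#N)C[C@H]1CN(c2ccc(-n3cc(-c4ccccn4)cn3)c(F)c2)C(=O)O1` — 64500 nM
Compound 2 `O=C1O[C@@H](CN2CCCCC2)CN1c1ccc(-n2cc(-c3ccccn3)cn2)c(F)c1` — 219000 nM

In a physicochemical assay for solubility, read by HPLC, with a stated time of 24 h (on this read-out higher numbers stand for higher solubility and lower numbers for lower solubility), compound 2 gives the highest of the two numbers; its nearest neighbour, compound 1, gives 64500 nM, and the step of a 3.4-fold higher number from compound 1 to compound 2 (0.53 log units; beyond the scatter) lies beyond the scatter. Compound 3 `O=C1O[C@@H](CN2CCC(c3ccc(F)cc3)CC2)CN1c1ccc(-n2cc(-c3ccccn3)cn2)c(F)c1` differs from compound 2 by 4-fluorophenyl in place of hydrogen on a saturated ring carbon. Within the data shown here, no measured step covers this change; the one known step, a 3.4-fold higher number from compound 1 to compound 2 (0.53 log units; beyond the scatter), concerns a different position and a different group. The added six-membered aromatic ring of seven heavy atoms is expected to lower the number, giving a 7.3-fold lower number from compound 2 to compound 3 (0.86 log units; beyond the scatter). Compound 3 is therefore estimated at 30000 nM, range 8000 nM to 110000 nM.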

Compound 3, solubility: <= 19400 nM
Compound 3 ended at the assay's limit; the forecaster's own chance of this, stated with the estimate: 5%; at least 1.5-fold (0.18 log units) between middle value and limit.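

Compound 1 and compound 2 showed only an exchange of the whole amine group; substitution on the ring carbon three ring bonds from the ring nitrogen is new here. In this assay, 4-fluorophenyl in place of hydrogen at that carbon gives an at least 11-fold lower number from compound 2 to compound 3 (1.05 log units; beyond the scatter), so this position can carry a large step. Compound 3 reads <= 19400 nM, which is a limit and not a number: the limit of <= 19400 nM in this assay, at which 1 of the 3 values shown sits.

Open, on these data alone, is how an unsubstituted phenyl or a small hydroxyl group at this carbon would read. Also open, as far as these compounds go, is whether a carboxylic acid or an amine on the added ring would bring the number off the limit.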